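Fluoro to chloro on the central ring

The source may hold more compounds than are shown below. What is called first, only, known or untested is meant among the compounds shown, and "the series" means these compounds.

Measured compounds:
compound 1, `Cc1nn(C)c(C)c1-c1ccc(-c2nnc(N(C)Cc3ccc4nccn4c3)o2)cc1`, 3.1
compound 2, `Cc1nn(C)c(C)c1-c1ccc(-c2nnc(N(C)Cc3ccc4nccn4c3)o2)c(F)c1`, 3.2

Of the compounds shown here, two that share one core have been measured in a physicochemical assay for lipophilicity, at pH 7.4; on this read-out lower numbers stand for lower lipophilicity and higher numbers for higher lipophilicity. Compound 1 is `Cc1nn(C)c(C)c1-c1ccc(-c2nnc(N(C)Cc3ccc4nccn4c3)o2)cc1` and in this assay compound 1 gives 3.1. For the measured compounds named here, compound 2 is `Cc1nn(C)c(C)c1-c1ccc(-c2nnc(N(C)Cc3ccc4nccn4c3)o2)c(F)c1` and in this assay compound 2 gives 3.2, the higher of the two numbers, with compound 1 as its only neighbour; the single measured step is a number 0.10 log units higher from compound 1 to compound 2 (within the scatter), so the two values are not separated beyond the scatter.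

Compound 3 is `Cc1nn(C)c(C)c1-c1ccc(-c2nnc(N(C)Cc3ccc4nccn4c3)o2)c(Cl)c1`, not yet measured. It differs from compound 2 in one place: chloro in place of fluoro on an aromatic carbon. No measured step exchanges fluoro for chloro, so the step from compound 2 to compound 3 has no direct precedent among these two compounds; the one step that bears on the same position, a number 0.10 log units higher from compound 1 to compound 2 (within the scatter), stayed within the scatter. A modest rise is nevertheless expected, a number 0.40 log units higher from compound 2 to compound 3 (beyond the scatter), and compound 3 is estimated at 3.6, within a range from 3.2 to 4.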

Compound 3, distribution coefficient: 3.3
The estimate for compound 3 lay 0.30 log units above the measured number; the measured number falls inside the stated range.
By their numbers in this assay, from the lowest: compounds 1, 2 and 3 (each within the scatter of the next).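

In this assay the exchange of fluoro for chloro on this aromatic carbon, ortho to a large group, reads as a number 0.10 log units higher from compound 2 to compound 3 (within the scatter) and the exchange of hydrogen for chloro reads as a number 0.20 log units higher from compound 1 to compound 3 (within the scatter) in the same series. For the compounds shown here, the earlier pair showed this for fluoro alone, whereas hydrogen, fluoro and chloro can now be set side by side at one position, and no step among them lies beyond the scatter. So on this core, a second halogen at this carbon gives no separation from either of the other two compounds, and no measurement available here offers an explanation for that result.

Whether any substituent at this carbon can give a step beyond the scatter in this assay remains open, since the compounds shown carry only hydrogen and two halogens there and say nothing of a methoxy group, a nitrile, a trifluoromethyl group or an amine. They also leave open whether chloro would read the same at another carbon of this ring, or with a group other than the 1,3,5-trimethyl-1H-pyrazol-4-yl group on the ring.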